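Estimating Compound 3 From Two Limits

The compounds below may be only part of what the source reports. "The series", "measured", "known", "first", "only" and "open" are said of these compounds alone.

- Compound 1 `C=CC(C)(C)c1[nH]c2ccc(C[C@@H](Cl)C(C)(C)O)cc2c1/C=C1\NC(=O)[C@H](C)NC1=O`: > 50000 nM, a limit
- Compound 2 `C=CC(C)(C)c1[nH]c2ccc(C[C@@H](O)C(=C)C)cc2c1/C=C1\NC(=O)[C@H](C)NC1=O`: > 50000 nM, a limit

Both results come from a functional assay on A459 cells (Homo sapiens) for cytotoxicity, read by sulforhodamine B assay, with a stated time of 24 h; on this read-out lower numbers stand for stronger inhibition and higher numbers for weaker inhibition. Compound 2 stands at a limit of the assay, > 50000 nM, and not at a true number. The same holds for all the data so far: the limit of > 50000 nM in this assay, at which 2 of the 2 values shown sit.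

Compound 3 `C=CC(C)(C)c1[nH]c2ccc(C[C@H]3OC(C)(C)OC3(C)C)cc2c1/C=C1\NC(=O)[C@H](C)NC1=O` carries 2,2,5,5-tetramethyl-1,3-dioxolan-4-yl in place of 1-hydroxy-2-methylprop-2-en-1-yl, on a saturated chain carbon bound to an aromatic carbon: 2,2,5,5-tetramethyl-1,3-dioxolan-4-yl in place of 1-hydroxy-2-methylprop-2-en-1-yl on a saturated chain carbon bound to an aromatic carbon. For the measured compounds named here, the only measured step, at this same place, is a step that the two limits leave unreadable from compound 1 to compound 2. It therefore offers no size to carry over, and no clear step is expected in this assay. Another limit is the likeliest result, because of the limit of > 50000 nM in this assay, at which 2 of the 2 values shown sit. The expected step is a number no higher from compound 2 to compound 3 (the limit leaves the size open). For compound 3 the estimated value is 50000 nM, with an expected range from 20000 nM to 100000 nM.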

Compound 3, half-maximal inhibitory concentration: > 50000 nM
Compound 3: a limit, no number; the forecaster's own chance of this, stated with the estimate: 85%; the middle value sits exactly at the limit.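

No step can be read among compound 1, compound 2 and compound 3 in this assay, because each result is a limit and not a true number: the limit of > 50000 nM in this assay, at which 3 of the 3 values shown sit.

Left open is whether these three compounds differ from one another at all, and whether any change at this place would give a true number.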